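Hydroxymethyl Added to the Pyrrolidin-1-yl Ring

The compounds below may be only part of what the source reports. "The series", "measured", "known", "first", "only" and "open" are said of these compounds alone.

Compound 3 `CN(C)/[N+]([O-])=N/Oc1cc(O/N=[N+](\[O-])N2CCCC2)c([N+](=O)[O-])cc1[N+](=O)[O-]` gives 2300 nM in a functional assay on HL-60 cells (Homo sapiens) for antiproliferative activity, read by MTT assay, with a stated time of 72 h (a lower number here means a stronger inhibitor, a higher number a weaker inhibitor), the highest of the three numbers, although both other compounds lie within the scatter of it: compound 1 `CCOC(=O)N1CCN(/[N+]([O-])=N/Oc2cc(O/N=[N+](\[O-])N(C)C)c([N+](=O)[O-])cc2[N+](=O)[O-])CC1` gives 1200 nM, and compound 2 `CC1CCCCN1/[N+]([O-])=N/Oc1cc(O/N=[N+](\[O-])N(C)C)c([N+](=O)[O-])cc1[N+](=O)[O-]` gives 1500 nM. The steps leading to compound 3 were small, a 1.9-fold higher number from compound 1 to compound 3 (0.28 log units; within the scatter) and a 1.5-fold higher number from compound 2 to compound 3 (0.19 log units; within the scatter), as was a 1.3-fold higher number from compound 1 to compound 2 (0.10 log units; within the scatter). Compound 4 `CN(C)/[N+]([O-])=N/Oc1cc(O/N=[N+](\[O-])N2CCCC2CO)c([N+](=O)[O-])cc1[N+](=O)[O-]` differs from compound 3 by hydroxymethyl in place of hydrogen on a saturated ring carbon. Within the data shown here, no measured step alters a ring carbon; all three exchange the whole ring on the double-bonded nitrogen, and each stayed within the scatter, so none bears directly on this change. Compound 4 is therefore expected to show no change at the digits printed from compound 3 to compound 4 (within the scatter), nothing beyond the scatter. Compound 4 is estimated at 2300 nM, within 1000 nM to 5500 nM.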

Compound 4, half-maximal inhibitory concentration: 1000 nM
For compound 4 the middle estimate is 2.3-fold (0.36 log units) above the measured one; the measured number falls inside the stated range.
By their numbers in this assay, from the lowest: compounds 4, 1, 2 and 3 (each within the scatter of the next, the first and the last beyond it).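

In this assay, among these compounds, hydroxymethyl on the saturated ring carbon next to the ring nitrogen gives the only step in this set beyond the scatter, a 2.3-fold lower number from compound 3 to compound 4 (0.36 log units; beyond the scatter), so this ring carbon, which no earlier step touched, does register a change. The change does not set the new ring apart from the other rings, as a 1.5-fold lower number from compound 2 to compound 4 (0.18 log units; within the scatter) and a 1.2-fold lower number from compound 1 to compound 4 (0.08 log units; within the scatter) both stay within the scatter. Nothing available explains the step. The compounds shown leave open how a methyl group, a carboxylic acid or an aminomethyl group on this ring carbon would compare. They also leave open whether hydroxymethyl would give a similar step on a piperidine ring.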